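Shifting the carboxyl on the anilino ring: an expected step

The source may hold more compounds than are shown below. What is called first, only, known or untested is meant among the compounds shown, and "the series" means these compounds.

Compound 2 `CN(C)/[N+]([O-])=N/Oc1cc(Nc2ccc(C(=O)O)cc2)c([N+](=O)[O-])cc1[N+](=O)[O-]` gives 73000 nM in a functional assay on NIH3T3 cells (Homo sapiens) for cytotoxicity against NIH3T3 (Mus musculus); on this read-out lower numbers stand for stronger inhibition and higher numbers for weaker inhibition. Compound 1 `CN(c1cccc(C(=O)O)c1)c1cc(O/N=[N+](\[O-])N(C)C)c([N+](=O)[O-])cc1[N+](=O)[O-]` gives 83000 nM in this assay, and the two values lie within the scatter of each other, so neither stands apart from the other. Compound 3 `CN(C)/[N+]([O-])=N/Oc1cc(Nc2cccc(C(=O)O)c2)c([N+](=O)[O-])cc1[N+](=O)[O-]` has not been measured; it differs from compound 2 by 3-carboxyphenyl in place of 4-carboxyphenyl on a nitrogen on an aromatic ring. Because compound 1 gives 83000 nM and compound 2 gives 73000 nM with a carboxyphenyl in either position on the same core, the expected step of a 1.0-fold higher number from compound 2 to compound 3 (0.01 log units; within the scatter) is none beyond the scatter. Compound 3 is estimated at 75000 nM, within a range from 35000 nM to 160000 nM.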

Compound 3, half-maximal inhibitory concentration in the NIH3T3 assay: 80000 nM
Estimate against measurement, compound 3: 1.1-fold (0.03 log units) below; the range from low to high includes it.
By their numbers in the NIH3T3 assay, from the lowest: compounds 2, 3 and 1 (each within the scatter of the next).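

In the NIH3T3 assay, neither the place of the carboxyl nor the methyl on the nitrogen separates these compounds, with a 1.1-fold higher number from compound 2 to compound 3 (0.04 log units; within the scatter) and a 1.0-fold lower number from compound 1 to compound 3 (0.02 log units; within the scatter). In a physicochemical assay for solubility, in phosphate buffer, at 37 degrees C (a higher number here means a more soluble compound, a lower number a less soluble compound), compound 2 gives > 3000000 nM, which is a limit of the assay. In the physicochemical assay compound 3 gives > 2000000 nM, again a limit, and the step between these two limits cannot be read.

Open, on these data alone, is whether a methyl ester or a primary amide in place of the carboxylic acid would leave the number in the NIH3T3 assay within the scatter. Also open, as far as these compounds go, is whether a longer chain than methyl on that nitrogen would do the same.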